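Chloro removal on the benzamide aryl of compound 2

The source may report more compounds than this note shows. Statements on the series, on what has been measured and on what is new or still open speak of the compounds shown alone.

Two members of this series have been measured in a functional assay on NCI-H522 cells (Homo sapiens) for inhibition, read by sulforhodamine B assay, with a stated time of 48 h; a lower number here means a stronger inhibitor of growth, a higher number a weaker inhibitor of growth. Compound 1 `O=C(Nc1cccc(-n2cc(-c3ccncc3)c(-c3ccc(Cl)c(O)c3)n2)c1)Nc1ccc(Cl)c(Cl)c1` gives 1190 nM in this assay. Compound 2 `COc1cc(-c2nn(-c3cccc(NC(=O)c4ccc(Cl)c(C(F)(F)F)c4)c3)cc2-c2ccncc2)ccc1Cl` gives 1040 nM in this assay, the lowest of the two numbers, though its gap to compound 1 lies within the scatter, so no order between them can be claimed. Within the data shown here, no pair of measured compounds differs in one place, so nothing is known yet about single changes on this core.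

Compound 3 `COc1cc(-c2nn(-c3cccc(NC(=O)c4cccc(C(F)(F)F)c4)c3)cc2-c2ccncc2)ccc1Cl` is the next compound for this assay. Its change from compound 2 is hydrogen in place of chloro on an aromatic carbon. Among the measured compounds shown here, with no measured step of this kind available, a step from compound 2 to compound 3 of a 1.5-fold higher number from compound 2 to compound 3 (0.19 log units; within the scatter) is expected, a mild weakening that may well fall within the scatter. Compound 3 is therefore estimated at 1600 nM, with a range from 600 nM to 4500 nM.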

Compound 3, concentration for 50% growth inhibition: 1050 nM
Compound 3: middle estimate off by 1.5-fold (0.18 log units), on the high side; measured number inside the range.
By their numbers in this assay, from the lowest: compounds 2, 3 and 1 (each within the scatter of the next).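

In this assay, among these compounds, going from 4-chloro-3-(trifluoromethyl)phenyl to 3-(trifluoromethyl)phenyl gives the first single-place comparison on the shared core (a 1.0-fold higher number from compound 2 to compound 3 (0.00 log units; within the scatter)), and the two compounds cannot be told apart. With the trifluoromethyl group in place, the chloro at this position, ortho to that group and para to a large group, is therefore not required to keep the number in this assay, as far as this one pair shows. No measurement at hand gives a reason for this result.

Going by these compounds, whether a larger or differently built group at the same position, such as an amine or a nitrile, would also leave the number within the scatter remains open. On these data alone, it is also open whether removing the chloro would read the same with a hydrogen in place of the trifluoromethyl group.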